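The source may hold more compounds than are shown below. What is called first, only, known or untested is meant among the compounds shown, and "the series" means these compounds.

Compound 1 `COc1cc(-c2nc(SCc3cn(CC(=O)NC(=O)Nc4ccccn4)nn3)nc(Nc3ccc(C(C)C)cc3)c2C#N)cc(OC)c1OC` and compound 2 `Cc1ccc(-c2nc(SCc3cn(CC(=O)NC(=O)Nc4ccccn4)nn3)nc(Nc3ccc(C(C)C)cc3)c2C#N)cc1` share one core and differ only in the aryl group on an aromatic carbon. In a functional assay on ECa-109 cells (Homo sapiens) for inhibition, read by MTT assay, with a stated time of 72 h (a lower number here means a stronger inhibitor, a higher number a weaker inhibitor), compound 1 gives only a limit, > 64000 nM. In this assay, among the measured compounds shown here, compound 2 gives 7450 nM, the single number obtained so far. The step of an at least 8.5-fold lower number from compound 1 to compound 2 (0.93 log units; beyond the scatter) is bounded by the limit (the limit of > 64000 nM in this assay, at which 1 of the 2 values shown sits). Compound 3 `COc1ccccc1Nc1nc(SCc2cn(CC(=O)NC(=O)Nc3ccccn3)nn2)nc(-c2ccc(C)cc2)c1C#N` differs from compound 2 by 2-methoxyphenyl in place of 4-isopropylphenyl on a nitrogen on an aromatic ring. For the measured compounds named here, no measured step touches this position, so neither size nor direction has a precedent here. Compound 3 is therefore expected to show a 1.3-fold higher number from compound 2 to compound 3 (0.13 log units; within the scatter) in this assay, a change not beyond the scatter. The estimate for compound 3 is 10000 nM, within 3000 nM to 40000 nM.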

Compound 3, half-maximal inhibitory concentration: 7850 nM
Estimate against measurement, compound 3: 1.3-fold (0.11 log units) above; low and high end bracket the measured number.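

The aryl group on the nitrogen on an aromatic ring now has a measured step in this assay: a 1.1-fold higher number from compound 2 to compound 3 (0.02 log units; within the scatter). Exchanging 4-isopropylphenyl for 2-methoxyphenyl, which brings in an oxygen and a hydrogen-bond acceptor, therefore does not separate the two compounds in this read-out. No measured property shown here bears on this step.

Still open, going by these compounds, is whether this position stays as flat with a group other than a substituted phenyl, such as a cyclohexyl ring or a longer alkyl chain. On these data alone, a carboxylic acid or an amine on the aryl ring is equally open.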